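A few compounds are considered here, and "the series" means these few. Any claim that something is new, unique, unknown or untested is made for them only; others in the source may bear on it.

Compound 2 `COc1ccc(-n2nc(C(=O)Nc3ccc(C)cc3)nc2-c2cc(OC)c(OC)c(OC)c2)cc1` gives 60% in a functional assay on the whole organism for inhibition, with Rattus norvegicus as the target, read by paw edema, with stated times of 30 min and 3 h, at a dose of 0.28 mmol/kg by the oral route (on this read-out higher numbers stand for more inhibition at the one dose given (going by the name of the read-out) and lower numbers for less inhibition), one of two measured numbers. Compound 1 `CCNC(=O)c1nc(-c2cc(OC)c(OC)c(OC)c2)n(-c2ccc(OC)cc2)n1` gives 69% in this assay. The step of a number 9 percentage points lower from compound 1 to compound 2 (within the scatter) put 4-methylphenyl in place of ethyl on an amide-type nitrogen and stayed within the scatter. Compound 3 `COc1ccc(-n2nc(C(=O)Nc3ccccc3)nc2-c2cc(OC)c(OC)c(OC)c2)cc1` differs from compound 2 in one place: hydrogen in place of methyl on an aromatic carbon. Among the measured compounds shown here, no measured step removes a methyl from an aromatic carbon; the only measured step, a larger change on the same amide-type nitrogen, moved the number within the scatter only. The step of a number 2 percentage points higher from compound 2 to compound 3 (within the scatter) is therefore expected to stay within the scatter. Compound 3 is estimated at 62%, between 46% and 78%.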

Compound 3, a percentage reported as inhibition, in the whole organism at one dose (the size of the read-out at that dose, not a potency): 54%
Beside the measured number, compound 3's estimate is 8 percentage points above it; the range from low to high includes it.
By their numbers in this assay, from the lowest: compounds 3, 2 and 1 (each within the scatter of the next, the first and the last beyond it).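

The step of a number 6 percentage points lower from compound 2 to compound 3 (within the scatter) in this assay shows that the methyl on this aromatic ring can be replaced by hydrogen without a change that can be told from the scatter. Among the compounds shown here, the step of a number 15 percentage points lower from compound 1 to compound 3 (beyond the scatter) is the first one beyond the scatter, so phenyl in place of ethyl on the amide-type nitrogen makes a modest difference, whereas 4-methylphenyl in place of ethyl stayed within it. Nothing available gives a reason for either step. The compounds shown leave open how a methoxy group or a chlorine atom in place of that methyl would read. As far as these compounds go, a propyl chain on the same nitrogen also remains open.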